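A Third Chloro Group Added to Compound 2

This account rests on a few compounds, and the source may have more. Where it says the series, first, only, none or still open, it means among the compounds named here.

compound 1 `C=C(c1ccc(F)cc1F)C1COC(C)(C)OO1`: only a limit, > 100000 nM
compound 2 `C=C(c1ccc(Cl)c(Cl)c1)C1COC2(CCCC2)OO1`: 50900 nM

Within the data shown here, in a functional assay on BEAS-2B cells (Homo sapiens) for inhibition, read by MTT assay, with a stated time of 72 h (a lower number here means a stronger inhibitor, a higher number a weaker inhibitor), compound 2 gives 50900 nM, the only number among the two values shown. Compound 1 gives no number, only the limit (the limit of > 100000 nM in this assay, at which 1 of the 2 values shown sits). Compound 3 `C=C(c1ccc(Cl)c(Cl)c1Cl)C1COC2(CCCC2)OO1` differs from compound 2 by chloro in place of hydrogen on an aromatic carbon. Among the measured compounds shown here, no step between measured compounds is available, so the size of this change in this assay is expected to be small, within the usual scatter, in no clear direction. Compound 3 is therefore expected near 40000 nM, between 15000 nM and 100000 nM, which amounts to an expected step of a 1.3-fold lower number from compound 2 to compound 3 (0.10 log units; within the scatter).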

Compound 3, half-maximal inhibitory concentration: 11500 nM
The estimate for compound 3 lay 3.5-fold (0.54 log units) above the measured number; measured number below the stated range.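

In this assay, chloro in place of hydrogen on the aromatic carbon, ortho to a chloro group and to a large group, gives a 4.4-fold lower number from compound 2 to compound 3 (0.65 log units; beyond the scatter). This is the first single change shown in the series, and it shows that the number responds to substitution at this position. Nothing measured here accounts for the step. Going by these compounds, whether a methyl, a methoxy or an amine at this position would move the number in the same way stays open, as does whether the chloro step carries over to compounds that differ elsewhere.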